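Para-substituted hydrazones on a shared triazole thioether core

This account rests on a few compounds, and the source may have more. Where it says the series, first, only, none or still open, it means among the compounds named here.

Measured so far:
compound 1 `O=C(CSc1nnc(-c2ccncc2)n1-c1ccccc1)N/N=C/c1ccccc1` — 23600 nM
compound 2 `COc1ccc(/C=N/NC(=O)CSc2nnc(-c3ccncc3)n2-c2ccccc2)cc1` — 23700 nM

Both compounds were read in a functional assay on MCF7 cells (Homo sapiens) for inhibition, read by MTT assay, with a stated time of 48 h; a higher number here means a weaker inhibitor, a lower number a stronger inhibitor. Compound 1 gives 23600 nM. Compound 2 gives 23700 nM, which on the two numbers to hand is nominally the higher of the pair, but the step of a 1.0-fold higher number from compound 1 to compound 2 (0.00 log units; within the scatter) is within the scatter, so the two are not distinguishable. Within the data shown here, that one step, methoxy in place of hydrogen on an aromatic carbon, is the only structural comparison available.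

Compound 3 `O=C(CSc1nnc(-c2ccncc2)n1-c1ccccc1)N/N=C/c1ccc([N+](=O)[O-])cc1` is not yet measured. It differs from compound 2 by nitro in place of methoxy on an aromatic carbon, a change on the same aromatic ring where the earlier step took place. Among the measured compounds shown here, no measured step bears directly on nitro in place of methoxy; the only neighbouring evidence, the step from compound 1 to compound 2, showed no movement beyond the scatter. Compound 3 is therefore expected to give 23000 nM in this assay, within 8000 nM to 65000 nM, a step of a 1.0-fold lower number from compound 2 to compound 3 (0.01 log units; within the scatter) expected to remain within the scatter.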

Compound 3, half-maximal inhibitory concentration: 15300 nM
The estimate for compound 3 lay 1.5-fold (0.18 log units) above the measured number; the measured number falls inside the stated range.
By their numbers in this assay, from the lowest: compounds 3, 1 and 2 (each within the scatter of the next).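

In this assay, the change from 4-methoxyphenyl to 4-nitrophenyl gives a 1.5-fold lower number from compound 2 to compound 3 (0.19 log units; within the scatter) at this place, and nitro in place of hydrogen gives a 1.5-fold lower number from compound 1 to compound 3 (0.19 log units; within the scatter) on the same aromatic carbon. The earlier pair compared only hydrogen and methoxy; with nitro, three different groups on this aromatic carbon, para to a large group, now stand within the scatter of one another, so none can be separated from the others in this read-out. No supporting data are available to explain these numbers.

From the compounds shown here alone, whether an amine, a carboxylic acid or a longer alkoxy chain at this place would give a step beyond the scatter remains open. The compounds shown also leave open how changes elsewhere on the shared core would read.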